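Compound 3 to compound 4: loss of the acyl side chain

A few compounds are considered here, and "the series" means these few. Any claim that something is new, unique, unknown or untested is made for them only; others in the source may bear on it.

Going by the values given here, in an ADME assay on L6 cells (Rattus norvegicus) for cytotoxicity, read by resazurin assay, with a stated time of 72 h (a higher number here means a weaker inhibitor, a lower number a stronger inhibitor), three compounds have numbers so far. Compound 1 (`NC1CC2(N3CCCC3)CC(c3ccccc3)C1C(c1ccccc1)C2`) gives 38100 nM in this measure, compound 2 (`CCN(CC)CC(=O)OC1CC2(N(C)C)CC(c3ccccc3)C1C(c1ccccc1)C2`) gives 30100 nM and compound 3 (`CN1CCN(CC(=O)NC2CC3(N(C)C)CC(c4ccccc4)C2C(c2ccccc2)C3)CC1`) gives 66200 nM on the same scale. Compound 3 stands clear of compound 2 but within the scatter of compound 1.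

Compound 4 (`CN(C)C12CC(N)C(C(c3ccccc3)C1)C(c1ccccc1)C2`) follows from compound 3 by a single change: hydrogen in place of ((4-methylpiperazin-1-yl)methyl)carbonyl on an amine nitrogen with hydrogen in place of ((4-methylpiperazin-1-yl)methyl)carbonyl on an amine nitrogen. An amino group remains there.

Among the compounds with values here, the only measured step at this place is a 2.2-fold higher number from compound 2 to compound 3 (0.34 log units; beyond the scatter) and it exchanges one side chain for another. Within the data shown here, no measured step removes a side chain outright, so it gives only a rough idea of size. Though it differs from compound 4 elsewhere, compound 1 also carries an amino group, and compound 1 at 38100 nM in this assay is the nearest guide. A modest move towards a lower number is therefore expected, and the estimated change is a 1.8-fold lower number from compound 3 to compound 4 (0.26 log units; within the scatter) in this measure. For compound 4 the expected value is 36000 nM with an estimated range from 16000 nM to 75000 nM in this assay terms.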

Compound 4, half-maximal inhibitory concentration: 40900 nM
The estimate for compound 4 lay 1.1-fold (0.06 log units) below the measured number; low and high end bracket the measured number.
By their numbers in this assay, from the lowest: compounds 2, 1, 4 and 3 (each within the scatter of the next, the first and the last beyond it).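

In this assay, stripping the ((4-methylpiperazin-1-yl)methyl)carbonyl group from the amine nitrogen and leaving hydrogen gives a 1.6-fold lower number from compound 3 to compound 4 (0.21 log units; within the scatter), so the outright loss of this side chain, unlike the earlier exchange of one side chain for another, is not separated from the scatter. The exchange of amino for (((diethylamino)methyl)carbonyl)oxy on the saturated ring carbon gives a 1.4-fold higher number from compound 2 to compound 4 (0.13 log units; within the scatter), so compound 4 lies within the scatter of both side-chain compounds, although those two stand apart from each other. Going by these compounds alone, the first reading at the other place, dimethylamino in place of pyrrolidin-1-yl on a saturated ring carbon, gives a 1.1-fold higher number from compound 1 to compound 4 (0.03 log units; within the scatter), and no measured information bears on these results.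

From the compounds shown here alone, whether a short acetyl group or a longer chain ending in a carboxylic acid on this amino group would move the number beyond the scatter remains open. At the other place, only dimethylamino and pyrrolidin-1-yl are compared, and a piperidin-1-yl group or a primary amine there remains untested in the compounds shown.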